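Adding a second hydroxymethyl to a weak cytotoxic scaffold

The source may hold more compounds than are shown below. What is called first, only, known or untested is meant among the compounds shown, and "the series" means these compounds.

Compound 1 `COC(=O)c1cc2n(c1C)[C@@H](c1ccccc1)SC2`: 56200 nM
Compound 2 `Cc1c(CO)cc2n1[C@@H](c1ccccc1)SC2`: 62900 nM
Compound 3 `Cc1c(COC(=O)NCc2ccccc2)cc2n1[C@@H](c1ccccc1)SC2`: 42100 nM

Of the compounds shown here, three on the shared core have been measured in a functional assay on A-375 cells (Homo sapiens) for cytotoxicity, read by MTT assay, with a stated time of 72 h; a higher number here means a weaker inhibitor, a lower number a stronger inhibitor. In this assay compound 1 gives 56200 nM, compound 2 gives 62900 nM, and compound 3 gives 42100 nM. Compound 2 does not stand apart from either of the others: compound 1 is nearest to it and compound 3 furthest, and both gaps fall within the scatter of repeated measurements, so nothing can be said about any ordering among the three.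

Compound 4 `Cc1c(CO)c(CO)c2n1[C@@H](c1ccccc1)SC2` differs from compound 2 in one place: hydroxymethyl in place of hydrogen on an aromatic carbon. Among the compounds with values here, only one measured step is available, and it concerns a different position: a 1.1-fold higher number from compound 1 to compound 2 (0.05 log units; within the scatter). That step shows that exchanging the group on the aromatic carbon left this assay unchanged beyond the scatter. Compound 3 and compound 2, which share the core and differ only in the substituent on that carbon, likewise show values that lie within the scatter of each other. Within the data shown here, no measured step introduces a group where compound 4 gains its hydroxymethyl, so there is no direct precedent for this change.

Given how little the measured changes on this core moved this assay, compound 4 is expected to give about 60000 nM, with a plausible range from 28000 nM to 130000 nM. The step this estimate implies, a 1.0-fold lower number from compound 2 to compound 4 (0.02 log units; within the scatter), is expected to remain within the scatter.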

Compound 4, half-maximal inhibitory concentration: 27200 nM
Compound 4: middle estimate off by 2.2-fold (0.34 log units), on the high side; the measured number lies below the stated range.
By their numbers in this assay, from the lowest: compounds 4, 3, 1 and 2 (each within the scatter of the next, the first and the last beyond it).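

In this assay, hydroxymethyl in place of hydrogen on this aromatic carbon gives a 2.3-fold lower number from compound 2 to compound 4 (0.36 log units; beyond the scatter), the first step on the shared core shown to lie beyond the scatter. The only earlier step, a 1.1-fold higher number from compound 1 to compound 2 (0.05 log units; within the scatter), lay within the scatter and concerned a different aromatic carbon, so this is the one place among the compounds shown where a single change moved the number, although the step is modest. Nothing available bears on why this change has this effect.

The compounds shown leave open whether the step belongs to hydroxymethyl specifically or would also follow from another group on the same carbon, such as an amine, a carboxylic acid or a longer chain like hydroxyethyl. They also leave open whether the step depends on the hydroxymethyl already present on the ring atom next to this carbon, or would hold with the benzyl carbamate of compound 3 or the methoxycarbonyl of compound 1 on that atom instead.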